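Adding a Bromo Substituent to a Quiet Series

The source may report more compounds than this note shows. Statements on the series, on what has been measured and on what is new or still open speak of the compounds shown alone.

Three measured compounds share one core and differ only on the phenyl ring at the end of the chain. Compound 1 `COc1cccc(C(O)CCn2nc3c(Br)c(Br)c(Br)c(Br)c3n2)c1` carries a methoxy group there; in a functional assay on CCRF-CEM cells (Homo sapiens) for antiproliferative activity, read by MTT assay, with a stated time of 48 h, tested at 50 uM (a higher number here means a weaker effect of the compound at the concentration tested, a lower number a stronger effect), compound 1 gives 2%. Compound 2 `OC(CCn1nc2c(Br)c(Br)c(Br)c(Br)c2n1)c1cccc(Cl)c1` carries chloro in place of methoxy, and compound 2 gives 0%. Compound 3 `OC(CCn1nc2c(Br)c(Br)c(Br)c(Br)c2n1)c1ccccc1` carries hydrogen in place of methoxy, and compound 3 gives 0%. The three steps between them are all small: a number 2 percentage points lower from compound 1 to compound 2 (within the scatter), a number 2 percentage points lower from compound 1 to compound 3 (within the scatter) and no change at the digits printed from compound 2 to compound 3 (within the scatter). Compound 3 thus stands level with compound 2 at the digits shown, the two together the lowest of three numbers, with compound 1 the furthest away and still within the scatter.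

Compound 4 `OC(CCn1nc2c(Br)c(Br)c(Br)c(Br)c2n1)c1ccc(Br)cc1` differs from compound 3 by one change: bromo in place of hydrogen on an aromatic carbon. Within the data shown here, the steps that bear on this are the swaps of one group for another on the same phenyl ring, a number 2 percentage points lower from compound 1 to compound 2 (within the scatter) and no change at the digits printed from compound 2 to compound 3 (within the scatter); neither moved the read-out beyond the scatter. One more such swap is therefore expected to leave the number essentially where it is, estimated as a step of a number 1 percentage points higher from compound 3 to compound 4 (within the scatter). Compound 4 is expected to give 1%, with an estimated range from 0% to 10%.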

Compound 4, a percentage reported as activity, at one concentration (the size of the read-out at that concentration, not a potency): 0%
Estimate against measurement, compound 4: 1 percentage points above, and the stated range covers the measured number.
By their numbers in this assay, from the lowest: compounds 2, 3, 4 and 1 (each within the scatter of the next).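

In this assay, among these compounds, this is the first look at a substituent in this place on the phenyl ring, para to a large group, and the first with bromo on that ring, yet the result is no change at the digits printed from compound 3 to compound 4 (within the scatter). The comparisons with the two rings substituted elsewhere, which differ in both the group and its place, read the same way: no change at the digits printed from compound 2 to compound 4 (within the scatter) and a number 2 percentage points lower from compound 1 to compound 4 (within the scatter), so neither 3-chlorophenyl, 3-methoxyphenyl nor 4-bromophenyl sets itself apart from the others at this single concentration. Nothing available here explains why the read-out stays put.

All four numbers lie within the scatter of one another, so these compounds leave open whether any group on this ring can move the read-out, for example an amine or a carboxylic acid in place of the bromo, or a longer chain between the ring and the shared core. They also leave open whether the four compounds would separate at a lower concentration, since a read-out taken at one concentration is not a potency.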